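This account rests on a few compounds, and the source may have more. Where it says the series, first, only, none or still open, it means among the compounds named here.

Measured compounds:
compound 1, `COc1ccc(CCCN2CCC(COCc3ccc(Cl)c(Cl)c3)CC2)cc1`, 200 nM
compound 2, `COc1ccc(CCCN2CCC(=CCC(c3ccccc3)c3ccccc3)CC2)cc1`, 400 nM
compound 3, `CCN1CCC(COC(c2ccccc2)c2ccccc2)CC1`, > 20000 nM

The three measured compounds share a piperidine core carrying an arm on the nitrogen and an ether or alkene arm on the ring carbon. In a functional assay on cells (T-cell line, Homo sapiens) for inhibition (a lower number here means a stronger inhibitor, a higher number a weaker inhibitor), compound 1 gives 200 nM and compound 2 gives 400 nM, two values within the usual scatter of each other. Compound 3 is different: its result in this assay is only a limit, > 20000 nM, as the limit of > 20000 nM in this assay, at which 1 of the 3 values shown sits, records, so no number is known for it beyond that boundary.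

Compound 4, `C(#Cc1ccccc1)CN1CCC(COC(c2ccccc2)c2ccccc2)CC1`, has not yet been measured in this assay. It differs from compound 3 in one place: 2-phenylethynyl in place of methyl on a saturated chain carbon bound to an amine nitrogen in a ring. Among the measured compounds shown here, no step between two measured compounds of this kind is available, so the size of the change can only be expected. Compounds 1 and 2, which carry a longer, aryl-bearing arm on the ring nitrogen, both fall well inside the measurable range, whereas compound 3 with its short ethyl does not. The extension from compound 3 to compound 4 is therefore expected to strengthen inhibition, estimated as a step of an at least 25-fold lower number from compound 3 to compound 4 (1.39 log units; beyond the scatter). For compound 4 the estimated value in this assay is 800 nM, expected to fall between 150 nM and 5000 nM.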

Compound 4, half-maximal inhibitory concentration: > 20000 nM
Compound 4 ended at the assay's limit (the forecaster's own chance of this, stated with the estimate: 10%); at least 25-fold (1.39 log units) between middle value and limit.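

Compound 3 and compound 4 both end at a limit in this assay, so no step can be read between them: the limit of > 20000 nM in this assay, at which 2 of the 4 values shown sit.

The compounds shown leave open whether 2-phenylethynyl in place of methyl changes inhibition at all.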